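From 4-chlorophenyl to 2,4-difluorophenyl at the assay limit

The compounds below may be only part of what the source reports. "The series", "measured", "known", "first", "only" and "open" are said of these compounds alone.

Measured in a functional assay on HepG2 cells (Homo sapiens) for inhibition, read by MTT assay, with a stated time of 72 h; a lower number here means a stronger inhibitor, a higher number a weaker inhibitor:
compound 1 `C=C[C@]1(C)C[C@@H](OC(=O)CNC(=O)Nc2cccc(Br)c2)[C@]2(C)[C@H](C)CC[C@]3(CCC(=O)[C@H]32)[C@@H](C)[C@@H]1O`: > 10000 nM
compound 2 `C=C[C@]1(C)C[C@@H](OC(=O)CNC(=O)NC(=O)c2ccc(Br)cc2)[C@]2(C)[C@H](C)CC[C@]3(CCC(=O)[C@H]32)[C@@H](C)[C@@H]1O`: > 10000 nM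
compound 3 `C=C[C@]1(C)C[C@@H](OC(=O)CNC(=O)Nc2ccc(Cl)cc2)[C@]2(C)[C@H](C)CC[C@]3(CCC(=O)[C@H]32)[C@@H](C)[C@@H]1O`: > 10000 nM

For compound 3 the reading of > 10000 nM is a limit of the assay and not a number. It has no numbered neighbour to stand against, as the series shows (the limit of > 10000 nM in this assay, at which 3 of the 3 values shown sit). Compound 4 `C=C[C@]1(C)C[C@@H](OC(=O)CNC(=O)Nc2ccc(F)cc2F)[C@]2(C)[C@H](C)CC[C@]3(CCC(=O)[C@H]32)[C@@H](C)[C@@H]1O` is the next case, with 2,4-difluorophenyl in place of 4-chlorophenyl on an amide-type nitrogen, which counts as 2,4-difluorophenyl in place of 4-chlorophenyl on an amide-type nitrogen. The measured steps nearest to this change replace the group on that same nitrogen. One is a step that the two limits leave unreadable from compound 1 to compound 3 and the other is a step that the two limits leave unreadable from compound 2 to compound 3. Neither gives a size or a direction to carry over, and a step that the two limits leave unreadable from compound 1 to compound 2 adds none. Among the compounds with values here, no step of definite size or direction is therefore expected in this assay, and a further limit is the likeliest report. The expected step is a step that the limit leaves unreadable from compound 3 to compound 4. For compound 4 the estimated inhibitory concentration is 15000 nM, with an expected range from 7000 nM to 40000 nM.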

Compound 4, half-maximal inhibitory concentration: > 10000 nM
Compound 4 was reported as a limit; the forecaster's own chance of this, stated with the estimate: 85%; the middle value does not contradict the limit.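

In this assay compound 4 gives > 10000 nM, which is a limit of the assay and not a number. The steps to compound 4 from compound 1, compound 2 and compound 3 therefore cannot be read: the limit of > 10000 nM in this assay, at which 4 of the 4 values shown sit.

The compounds shown leave open whether any group on that amide-type nitrogen would give a numbered value in this assay.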